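From cyano to methoxy: a clearance forecast

The source may report more compounds than this note shows. Statements on the series, on what has been measured and on what is new or still open speak of the compounds shown alone.

In an in vitro ADME assay on microsomes from liver (Homo sapiens) for metabolic stability (a higher number here means faster removal of the compound, a lower number slower removal), compound 1 (`c1ccc(C2Cc3nccn3C2)cc1`) gives 15 mL.min-1.g-1; < 7 mL.min-1.g-1 (2 entries) over two entries. Compound 2 (`N#Cc1ccccc1C1Cc2nccn2C1`) stands at < 7 mL.min-1.g-1 as a limit and not a number. Compound 3 (`COc1ccccc1C1Cc2nccn2C1`) carries methoxy in place of cyano on an aromatic carbon. For the measured compounds named here, no measured step covers this swap. The expected change is a modest rise in this assay, estimated as an at least 1.8-fold higher number from compound 2 to compound 3 (0.26 log units; that floor lies within the scatter) and perhaps only just beyond the scatter. Compound 3 is estimated at 13 mL.min-1.g-1 with 7 mL.min-1.g-1 to 35 mL.min-1.g-1 as its expected range.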

Compound 3, intrinsic clearance in microsomes: 37 mL.min-1.g-1
Compound 3: the middle estimate sits 2.8-fold (0.45 log units) below what was measured; the whole stated range lies below it.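

In this assay the group on this aromatic carbon proves to matter, with an at least 5.2-fold higher number from compound 2 to compound 3 (0.72 log units; beyond the scatter) when methoxy replaces cyano. Compound 2 gives < 7 mL.min-1.g-1 as a limit and not a number. From the compounds shown here alone, the true size of the step therefore stays unknown, because one end of it rests on such a limit: the limit of < 7 mL.min-1.g-1 in this assay, at which 1 of the 3 values shown sits.

Going by these compounds, whether the change comes from gaining methoxy or from losing cyano stays open. The compounds shown also do not tell how fluorine, an amine or a longer chain such as ethoxy would behave on this carbon.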